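Replacing acetyl with 4-chlorobenzoyl on a shared benzimidazole-piperazine core

A few compounds are considered here, and "the series" means these few. Any claim that something is new, unique, unknown or untested is made for them only; others in the source may bear on it.

Measured so far:
- compound 1, `Cc1cccc(Cn2c(CN3CCN(C(=O)c4ccc(C(F)(F)F)cc4)CC3)nc3ccccc32)c1`: 22.9%
- compound 2, `CCc1ccc(C(=O)N2CCN(Cc3nc4ccccc4n3Cc3cccc(C)c3)CC2)cc1`: 67%
- compound 3, `CC(=O)N1CCN(Cc2nc3ccccc3n2Cc2cccc(C)c2)CC1`: 70.3%

In an assay on isolated protein for inhibition of aldehyde dehydrogenase 1A1 (Homo sapiens), read by spectrophotometry, tested at 10 uM (on this read-out lower numbers stand for less inhibition and higher numbers for more inhibition at the one concentration tested (going by the name of the read-out)), compound 3 gives the highest of the three numbers, though compound 2 sits within the scatter of it, while compound 1 lies far lower. Compound 4, `Cc1cccc(Cn2c(CN3CCN(C(=O)c4ccc(Cl)cc4)CC3)nc3ccccc32)c1`, is not yet measured. It differs from compound 3 in one place: 4-chlorophenyl in place of methyl on a carbonyl carbon. For the measured compounds named here, two measured steps bear on this change, since both put an aryl group in place of a small group on the same carbonyl carbon. The step of a number 3.3 percentage points higher from compound 2 to compound 3 (within the scatter) shows that a 4-ethylphenyl group in this position costs nothing beyond the scatter, whereas the step of a number 47.4 percentage points higher from compound 1 to compound 3 (beyond the scatter) shows that a 4-(trifluoromethyl)phenyl group costs a large amount. A 4-chlorophenyl group therefore is expected to land somewhere between these two outcomes in this assay, with a moderate drop as the more likely result, so the step of a number 22.3 percentage points lower from compound 3 to compound 4 (beyond the scatter) is expected to be downward. Compound 4 is estimated at 48%, within a range from 22% to 72%.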

Compound 4, a percentage reported as inhibition, at one concentration (the size of the read-out at that concentration, not a potency): 23.2%
The estimate for compound 4 lay 24.8 percentage points above the measured number, and the stated range covers the measured number.
By their numbers in this assay, from the lowest: compounds 1 and 4 (each within the scatter of the next); then compounds 2 and 3 (each within the scatter of the next).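

In this assay, 4-chlorophenyl in place of methyl on a carbonyl carbon gives a number 47.1 percentage points lower from compound 3 to compound 4 (beyond the scatter) and so shows that an aryl group here can carry a large loss, though compound 2 goes against any rule that all aryl groups do. What sets these aryl groups apart is the group on their aromatic carbon: chloro in place of ethyl gives a number 43.8 percentage points lower from compound 2 to compound 4 (beyond the scatter) and then chloro in place of trifluoromethyl gives a number 0.3 percentage points higher from compound 1 to compound 4 (within the scatter) as the second comparison, so chloro and trifluoromethyl fall together, apart from ethyl. No measurement offers a reason for this split.

Going by these compounds, whether a methoxy group, a propyl chain or a carboxylic acid on that aromatic carbon would fall with ethyl or with chloro remains open. So does the outcome for a phenyl ring with no added group.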